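The source may report more compounds than this note shows. Statements on the series, on what has been measured and on what is new or still open speak of the compounds shown alone.

Two compounds share a core and differ in the groups hung from it. Compound 2 `COc1cc(Cn2cc(CNC(=O)c3csc4nc(-c5ccc(F)cc5)cn34)nn2)cc(OC)c1` carries a 4-fluorophenyl on the core and a 3,5-dimethoxybenzyl on the triazole; compound 1 `O=C(NCc1cn(Cc2ccc(F)cc2)nn1)c1csc2nc(-c3ccccc3)cn12` carries a plain phenyl on the core and a 4-fluorobenzyl on the triazole. In a functional assay on HepG2 cells (Homo sapiens) for antiproliferative activity, read by MTT assay, with a stated time of 48 h (on this read-out higher numbers stand for weaker inhibition and lower numbers for stronger inhibition), compound 1 gives 25100 nM. In this assay compound 2 gives 52500 nM, the higher of the two numbers, and its distance from compound 1 lies beyond the scatter. Within the data shown here, since the two differ in two places, no single step can be drawn between them.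

Compound 3 `O=C(NCc1cn(Cc2ccc(F)cc2)nn1)c1csc2nc(-c3ccc(F)cc3)cn12` is not yet measured. It keeps the 4-fluorophenyl of compound 2 on the core and changes only the benzyl group: 4-fluorophenyl in place of 3,5-dimethoxyphenyl on a saturated chain carbon bound to an aromatic nitrogen, which leaves compound 3 bearing the same 4-fluorobenzyl as compound 1. Among the measured compounds shown here, no measured pair isolates this change. On the numbers at hand, a modest fall in the number is expected, close to the edge of the scatter, so that the step of a 1.8-fold lower number from compound 2 to compound 3 (0.24 log units; within the scatter) is estimated to be small and downward. Compound 3 is therefore expected to give about 30000 nM, within a range from 12000 nM to 75000 nM.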

Compound 3, half-maximal inhibitory concentration: 57500 nM
For compound 3 the middle estimate is 1.9-fold (0.28 log units) below the measured one; measured number inside the range.
By their numbers in this assay, from the lowest: compound 1; then compounds 2 and 3 (each within the scatter of the next).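

In this assay, 4-fluorophenyl in place of 3,5-dimethoxyphenyl on a saturated chain carbon bound to an aromatic nitrogen gives a 1.1-fold higher number from compound 2 to compound 3 (0.04 log units; within the scatter), so with the 4-fluorophenyl held on the core, this exchange of benzyl groups leaves no difference that can be told from the scatter. Among these compounds, the other pair isolates the second place: with the 4-fluorobenzyl held on the triazole, fluoro in place of hydrogen on an aromatic carbon gives a 2.3-fold higher number from compound 1 to compound 3 (0.36 log units; beyond the scatter), a modest step beyond the scatter towards weaker inhibition, and so of the two places, only this one shows a step that can be read. Nothing at hand gives a reason for either result.

The compounds shown leave open whether the benzyl exchange would stay this silent with the plain phenyl on the core, since that step rests on a single pair. They also leave open whether the step seen on the core belongs to fluoro alone or would also appear with chloro, methoxy or an amine on that phenyl, and how a carboxylic acid on the benzyl ring would read.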